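Trimming the branched chain of compound 1: isobutyl to propyl

A few compounds are considered here, and "the series" means these few. Any claim that something is new, unique, unknown or untested is made for them only; others in the source may bear on it.

In an assay on CHO cells for displacement of a labelled ligand from prostaglandin D2 receptor 2 (Homo sapiens), read by scintillation counting (on this read-out lower numbers stand for stronger inhibition and higher numbers for weaker inhibition), compound 1 `CC(C)Cc1ccncc1C#Cc1cc(Cl)ccc1OCC(=O)O` gives 4.9 nM, the lowest of the two numbers at hand; compound 2 `O=C(O)COc1ccc(Cl)cc1C#Cc1cccc(C(F)(F)F)c1` gives 92 nM, a gap beyond the scatter. Compound 3 `CCCc1ccncc1C#Cc1cc(Cl)ccc1OCC(=O)O` differs from compound 1 by hydrogen in place of methyl on a saturated chain carbon bound to two saturated chain carbons, which reads isobutyl to propyl. Within the data shown here, no step of this kind has been measured, so its size in this assay can only be expected: the loss of the methyl is expected to shift the number upward a little, at or near the edge of the scatter. The step expected here is a 1.8-fold higher number from compound 1 to compound 3 (0.26 log units; within the scatter). Compound 3 is expected to give 9 nM, within 3.5 nM to 25 nM.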

Compound 3, inhibition constant: 4.3 nM
Estimate against measurement, compound 3: 2.1-fold (0.32 log units) above; the range from low to high includes it.
By their numbers in this assay, from the lowest: compounds 3 and 1 (each within the scatter of the next); then compound 2.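

In this assay, the step for this change is a 1.1-fold lower number from compound 1 to compound 3 (0.06 log units; within the scatter), so isobutyl and propyl cannot be told apart at this position. Among these compounds, this is the first reading of the change, and it shows that the methyl can leave the saturated chain carbon without a step beyond the scatter. Nothing at hand explains why the two chains read alike.

The compounds shown leave open whether a shorter chain such as ethyl, a longer chain such as pentyl, or an ether oxygen within the chain would hold the number in this range.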